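This account rests on a few compounds, and the source may have more. Where it says the series, first, only, none or still open, it means among the compounds named here.

In a functional assay on NCI-H460 cells (Homo sapiens) for inhibition, read by sulforhodamine B assay, with a stated time of 72 h (on this read-out higher numbers stand for weaker inhibition and lower numbers for stronger inhibition), compound 1 (`CCNC(=O)c1nnn(-c2cc(C(C)C)c(O)cc2O)c1-c1ccc(CN2CCCC2)cc1`) gives 3 nM and compound 2 (`CCNC(=O)c1nnn(-c2cc(C(C)C)c(O)cc2O)c1-c1ccc(CN2CCNCC2)cc1`) gives 250 nM as the higher of the two numbers, which makes compound 2 the weaker inhibitor of this pair. Putting piperazin-1-yl in place of pyrrolidin-1-yl gives an 83-fold higher number from compound 1 to compound 2 (1.92 log units; beyond the scatter) as a large step, beyond the scatter. Compound 3 (`CCNC(=O)c1nnn(-c2cc(C(C)C)c(O)cc2O)c1-c1ccc(CNCC2CCCCC2)cc1`) changes that same place again, with (cyclohexylmethyl)amino in place of piperazin-1-yl on a saturated chain carbon bound to an aromatic carbon as its difference from compound 2. For the measured compounds named here, only this one measured step bears on the change. On these data alone, it shows that the number moves strongly with the group at this place and that piperazin-1-yl sits on the high side, but the entering group is untested. The expected step is an 8.3-fold lower number from compound 2 to compound 3 (0.92 log units; beyond the scatter) towards stronger inhibition, probably smaller than the measured one. In this assay compound 3 is estimated at 30 nM within an expected range from 6 nM to 150 nM for now.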

Compound 3, half-maximal inhibitory concentration: 2.1 nM
Compound 3: middle estimate off by 14-fold (1.15 log units), on the high side; measured number below the stated range.
By their numbers in this assay, from the lowest: compounds 3 and 1 (each within the scatter of the next); then compound 2.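

In this assay the step is a 120-fold lower number from compound 2 to compound 3 (2.08 log units; beyond the scatter) and shows that a high number is not the rule for a six-membered ring in the group at this place, since compound 3 also carries one, with carbon only, and has more heavy atoms in the entering group than compound 2 has in the leaving one. For the compounds shown here, the comparison with the pyrrolidine compound is a 1.4-fold lower number from compound 1 to compound 3 (0.15 log units; within the scatter) and cannot separate (cyclohexylmethyl)amino from pyrrolidin-1-yl, so piperazin-1-yl is the only one of the three groups that stands apart. Nothing given here explains why piperazin-1-yl behaves differently.

On these data alone, whether the second ring nitrogen of piperazin-1-yl is tied to the high number remains open, and morpholin-4-yl or 4-methylpiperazin-1-yl at this place would bear on that question. A plain cyclohexylamino group would show whether the extra methylene link in (cyclohexylmethyl)amino matters.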